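Swapping a Pyridine for a Furan on a Piperazine Nitrogen

The source may report more compounds than this note shows. Statements on the series, on what has been measured and on what is new or still open speak of the compounds shown alone.

Measured compounds:
- compound 1 `Cc1ncc([N+](=O)[O-])n1CC(O)CSC(=S)N1CCN(c2cccc(Cl)c2)CC1` gives 1080000 nM
- compound 2 `Cc1ncc([N+](=O)[O-])n1CC(O)CSC(=S)N1CCCC(C)C1` gives 609000 nM
- compound 3 `Cc1ncc([N+](=O)[O-])n1CC(O)CN1CCN(c2ccccn2)CC1` gives 1830000 nM

In a toxicity assay on HeLa cells (Homo sapiens) for cytotoxicity, read by MTT assay, with a stated time of 24 h (on this read-out higher numbers stand for weaker inhibition and lower numbers for stronger inhibition), compound 3 gives 1830000 nM, the highest of the three numbers; compound 1 gives 1080000 nM, which lies within the scatter of that, while compound 2 gives 609000 nM, a gap beyond the scatter. Compound 4 `Cc1ncc([N+](=O)[O-])n1CC(O)CN1CCN(c2ccco2)CC1` differs from compound 3 only by furan-2-yl in place of pyridin-2-yl on an amine nitrogen in a ring. For the measured compounds named here, no measured pair shows what such a change does here, so no clear direction can be drawn. The step from compound 3 to compound 4 is therefore expected to stay within the scatter, as a 1.2-fold lower number from compound 3 to compound 4 (0.09 log units; within the scatter). Compound 4 is estimated at 1500000 nM, with a range of 700000 nM to 3200000 nM.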

Compound 4, half-maximal inhibitory concentration: 3520000 nM
Estimate against measurement, compound 4: 2.3-fold (0.37 log units) below, outside the stated range (above it).
By their numbers in this assay, from the lowest: compounds 2, 1, 3 and 4 (each within the scatter of the next, the first and the last beyond it).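

In this assay, furan-2-yl in place of pyridin-2-yl on an amine nitrogen in a ring gives a 1.9-fold higher number from compound 3 to compound 4 (0.28 log units; within the scatter) for this first measured pair at this position. A five-membered aromatic ring holding oxygen can therefore replace a six-membered aromatic ring holding nitrogen without a clear shift in the number. Nothing available explains this small step. Going by these compounds, whether a carboxylic acid or a longer chain on that same nitrogen would move the number beyond the scatter remains open.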